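Benzyl amide in place of dimethylphenyl anilide

The compounds below may be only part of what the source reports. "The series", "measured", "known", "first", "only" and "open" are said of these compounds alone.

Compound 1 `Cc1ccc(NC(=O)c2cccc(/C=C3\CC(=O)N(c4ccccc4)C3=O)c2)cc1C` carries a 3,4-dimethylphenyl group on its amide nitrogen. In an ADME assay on SW480 cells (Homo sapiens) for cytotoxicity, read by MTT assay, with a stated time of 72 h (on this read-out higher numbers stand for weaker inhibition and lower numbers for stronger inhibition), compound 1 gives > 100000 nM, which is a limit of the assay and not a number. Two related compounds share the same core. Compound 2 `CCCCCN1C(=O)C/C(=C\c2cccc(C(=O)Nc3cccc(CC)c3)c2)C1=O` gives 83300 nM in this assay. Compound 3 `Cc1ccc(N2C(=O)C/C(=C\c3cccc(C(=O)Nc4ccc(Cl)cc4)c3)C2=O)cc1` gives > 100000 nM in this assay, again a limit. Compound 1 therefore stands at the limit of > 100000 nM in this assay, at which 2 of the 3 values shown sit, so its place among the three can only be given as a limit, with one measured number near it.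

Compound 4 `O=C(NCc1ccccc1)c1cccc(/C=C2\CC(=O)N(c3ccccc3)C2=O)c1` differs from compound 1 in one place: benzyl in place of 3,4-dimethylphenyl on an amide-type nitrogen. No measured step between these compounds exists, so the size of the change is not known from the numbers shown. Given that compound 1 itself sits at the limit, the step from compound 1 to compound 4 is expected to be none beyond the scatter, with a fair chance that compound 4 also returns only a limit, as a number no higher from compound 1 to compound 4 (the limit leaves the size open) expresses. Compound 4 is accordingly estimated at 100000 nM in this assay, within the range 50000 nM to 200000 nM.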

Compound 4, half-maximal inhibitory concentration: > 100000 nM
Compound 4: only a limit was reported (the forecaster's own chance of this, stated with the estimate: 60%); the middle value lies on the limit itself.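

Compound 4 gives > 100000 nM, a limit of the assay and not a number. Compound 1 also stands at a limit, so no step can be read between compound 1 and compound 4. The compounds shown leave open whether benzyl and 3,4-dimethylphenyl on the amide-type nitrogen differ at all, and most values stand at one point: the limit of > 100000 nM in this assay, at which 3 of the 4 values shown sit.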